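Amine to Alcohol: A One-Atom Swap and Its Expected Effect

The source may report more compounds than this note shows. Statements on the series, on what has been measured and on what is new or still open speak of the compounds shown alone.

Of the compounds shown here, two have been tested so far in a functional assay on the whole organism (strain Wistar) for inhibition, with Rattus norvegicus as the target, at a dose of 25 mg/kg by the oral route; a higher number here means more inhibition at the dose given (going by the name of the read-out), a lower number less inhibition. Compound 1 `COc1ccc(C#CC(C)(C)N)cc1-c1[nH]nc2nc(Nc3ccc(F)cc3F)ccc12` gives 49% in this assay. Compound 2 `COc1ccc(C#CC(C)(C)N)cc1-c1[nH]nc2nc(Nc3ccc(F)cc3F)cnc12`, which shares the same outer groups on a different core, gives 37% in this assay, the lower of the two numbers, with the gap to compound 1 larger than the usual scatter.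

The next compound, compound 3 `COc1ccc(C#CC(C)(C)O)cc1-c1[nH]nc2nc(Nc3ccc(F)cc3F)cnc12`, is not yet measured. It differs from compound 2 in one place: hydroxy in place of amino on a saturated chain carbon bound to two saturated chain carbons and a triple-bonded carbon. The side chain keeps its length and shape; only the atom carrying the hydrogen changes.

Going by the values given here, with no measured pair showing this same swap, the size of the step is open. Compound 3 is expected to land near compound 2, at 32% in this assay, within a range of 15% to 47%, which means a step of a number 5 percentage points lower from compound 2 to compound 3 (within the scatter) that is estimated to stay close to the scatter rather than clearly beyond it.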

Compound 3, a percentage reported as inhibition, in the whole organism at one dose (the size of the read-out at that dose, not a potency): 41%
The estimate for compound 3 lay 9 percentage points below the measured number, within the range that was stated.
By their numbers in this assay, from the lowest: compounds 2, 3 and 1 (each within the scatter of the next, the first and the last beyond it).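

In this assay, hydroxy in place of amino on a saturated chain carbon bound to two saturated chain carbons and a triple-bonded carbon gives a number 4 percentage points higher from compound 2 to compound 3 (within the scatter), so this pair does not separate the two groups at this place. On this core, the read-out at the single oral dose therefore does not depend measurably on whether this place carries nitrogen or oxygen, two groups that count the same under hydrogen-bond donors and acceptors. Nothing available here bears on why the two groups read alike.

As far as these compounds go, whether the same swap would also leave the number unchanged on the core of compound 1 stays open. So does whether a larger change at this place, such as a methyl ether, a carboxylic acid or a longer chain, would move the result in this assay beyond the scatter.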